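Adding a Phenylethyl Group to the Amide Head

The source may hold more compounds than are shown below. What is called first, only, known or untested is meant among the compounds shown, and "the series" means these compounds.

compound 1 `Cc1nc(-c2ccc(C(F)(F)F)cc2)sc1CNc1ccc(C(=O)O)cc1`: in a functional assay on CHO cells for agonist activity at Free fatty acid receptor 1 (Homo sapiens) (a lower number here means that less compound is needed, a higher number that more compound is needed for the effect), a limit of the assay, < 10000 nM
compound 2 `Cc1nc(-c2ccc(C(F)(F)F)cc2)sc1CNc1ccc([C@H]2C[C@@H]2C(N)=O)cc1`: in this assay 4.47 nM

For the measured compounds named here, compound 2 holds the only real number here; the value of compound 1 is a limit, not a number (the limit of < 10000 nM in this assay, at which 1 of the 2 values shown sits). Going by the values given here, the one measured step, a step that the limit leaves unreadable from compound 1 to compound 2, is therefore unreadable and gives no guide. Compound 3 `Cc1nc(-c2ccc(C(F)(F)F)cc2)sc1CNc1ccc([C@H]2C[C@@H]2C(=O)N[C@H](C)c2ccccc2)cc1` carries 1-phenylethyl in place of hydrogen on an amide-type nitrogen. Among the compounds with values here, no measured step bears on this change, so the expectation rests on compound 2 alone, widened for the unknown. Compound 3 is expected to give 30 nM, in the range 5 nM to 300 nM. The expected step is a 6.7-fold higher number from compound 2 to compound 3 (0.83 log units; beyond the scatter), a modest loss.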

Compound 3, half-maximal effective concentration: 53.7 nM
For compound 3 the middle estimate is 1.8-fold (0.25 log units) below the measured one; the range from low to high includes it.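

In this assay, for the compounds shown here, 1-phenylethyl in place of the hydrogen on the amide-type nitrogen is a 12-fold higher number from compound 2 to compound 3 (1.08 log units; beyond the scatter), the first step that can be read. Compound 3 still gives 53.7 nM, so this nitrogen can carry this added group, though at a clear cost in potency. Nothing measured here explains the size of that loss.

Still open, going by these compounds, is whether a methyl or a benzyl group on this nitrogen would cost less. The compounds shown also leave open how the mirror-image form of the 1-phenylethyl stereocentre would behave.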